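Two Measured Ureas and an Aryl Swap on the Anilino Nitrogen

The source may hold more compounds than are shown below. What is called first, only, known or untested is meant among the compounds shown, and "the series" means these compounds.

Measured compounds:
Compound 1 `Cc1cc(F)cc(Nc2cc(NC(=O)Nc3c(Cl)cccc3Cl)ncn2)c1`: 65.1%
Compound 2 `COc1cc(NC(=O)Nc2cc(Nc3cccc(C(C)(C)C)c3)ncn2)cc(OC)c1`: 35.1%

In a functional assay on NCI-H1581 cells (Homo sapiens) for inhibition, read by MTT assay, with a stated time of 48 h, tested at 10 uM (a lower number here means less inhibition, a higher number more inhibition at the concentration tested (going by the name of the read-out)), compound 2 gives 35.1%, the lower of the two numbers, with compound 1 standing higher by a margin beyond the usual scatter. Compound 3 `COc1cc(NC(=O)Nc2cc(Nc3cc(I)ccc3OC)ncn2)cc(OC)c1` is not yet measured. It differs from compound 2 by 5-iodo-2-methoxyphenyl in place of 3-(tert-butyl)phenyl on a nitrogen on an aromatic ring. Among the compounds with values here, no measured pair isolates this change, so the step from compound 2 is uncertain; a small rise in this assay, or none beyond the scatter, is expected. Compound 3 is accordingly estimated at 40%, within 15% to 65%, implying an expected step of a number 4.9 percentage points higher from compound 2 to compound 3 (within the scatter).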

Compound 3, a percentage reported as inhibition, at one concentration (the size of the read-out at that concentration, not a potency): 59%
The estimate for compound 3 lay 19 percentage points below the measured number; the range from low to high includes it.
By their numbers in this assay, from the lowest: compound 2; then compounds 3 and 1 (each within the scatter of the next).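

On the aromatic nitrogen of the shared core, the aryl group is not a silent position in this assay: 5-iodo-2-methoxyphenyl in place of 3-(tert-butyl)phenyl gives a number 23.9 percentage points higher from compound 2 to compound 3 (beyond the scatter) for this urea series. The swap brings in an iodine and a methoxy group and removes the tert-butyl group in a single move, so the step belongs to the whole aryl group and not to any one of these. Nothing measured here bears on why the number moves.

On these data alone, it remains open whether the iodine or the methoxy group alone would give this step. Also open, as far as these compounds go, is how an amine or a carboxylic acid on this aryl ring would read.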